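The source may report more compounds than this note shows. Statements on the series, on what has been measured and on what is new or still open speak of the compounds shown alone.

Measured compounds:
- compound 1 `CC[C@H](C)[C@@H](NC(=O)Cn1cc(C2=C(c3c[nH]c4ccccc34)C(=O)N(C)C2=O)c2ccccc21)C(=O)OC`: in a functional assay on Bel-7402 cells (Homo sapiens) for cytotoxicity, read by MTT assay, with a stated time of 24 h (on this read-out higher numbers stand for weaker inhibition and lower numbers for stronger inhibition), compound 1 gives > 100000 nM, which is a limit of the assay, not a number (the limit of > 100000 nM in this assay, at which 1 of the 3 values shown sits).
- compound 2 `COC(=O)[C@@H](C)NC(=O)Cn1cc(C2=C(c3c[nH]c4ccccc34)C(=O)N(C)C2=O)c2ccccc21`: compound 2 gives 9340 nM.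
- compound 3 `COC(=O)[C@H](NC(=O)Cn1cc(C2=C(c3c[nH]c4ccccc34)C(=O)N(C)C2=O)c2ccccc21)C(C)C`: compound 3 gives 4010 nM.

Compound 3 stands lowest of the two numbers obtained, the nearest being compound 2 at a 2.3-fold lower number from compound 2 to compound 3 (0.37 log units; beyond the scatter); the other value is only a limit. Compound 4 `COC(=O)CC[C@@H](NC(=O)Cn1cc(C2=C(c3c[nH]c4ccccc34)C(=O)N(C)C2=O)c2ccccc21)C(=O)OC` has not been measured. It differs from compound 3 by 2-(methoxycarbonyl)ethyl in place of isopropyl on a saturated chain carbon bound to an amide-type nitrogen and a carbonyl carbon. Going by the values given here, the steps that bear on this site are an at least 10-fold lower number from compound 1 to compound 2 (1.02 log units; beyond the scatter) and a 2.3-fold lower number from compound 2 to compound 3 (0.37 log units; beyond the scatter), both changing the group on the saturated chain carbon bound to an amide-type nitrogen and a carbonyl carbon; the first large, the second modest. Among the compounds with values here, no measured step introduces a 2-(methoxycarbonyl)ethyl group or any ester-bearing chain at this site, so the direction is not fixed by the data. The expected step for compound 4 is a 1.6-fold higher number from compound 3 to compound 4 (0.21 log units; within the scatter), a small rise in number with wide uncertainty. Compound 4 is therefore expected to give 6500 nM, in the range 2000 nM to 25000 nM.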

Compound 4, half-maximal inhibitory concentration: 47400 nM
Beside the measured number, compound 4's estimate is 7.3-fold (0.86 log units) below it, outside the stated range (above it).
By their numbers in this assay, from the lowest: compound 3; then compound 2; then compound 4. At a limit, above all of these: compound 1.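

In this assay, placing 2-(methoxycarbonyl)ethyl on the saturated chain carbon bound to an amide-type nitrogen and a carbonyl carbon gives a 12-fold higher number from compound 3 to compound 4 (1.07 log units; beyond the scatter) and a 5.1-fold higher number from compound 2 to compound 4 (0.71 log units; beyond the scatter), so this ester-bearing chain stands on the high side of both isopropyl and methyl at this position. Against sec-butyl, the change reads as an at least 2.1-fold lower number from compound 1 to compound 4 (0.32 log units; beyond the scatter), so compound 4 does not reach the top of the series. Compound 1 is held only by a limit of the assay, not a number: the limit of > 100000 nM in this assay, at which 1 of the 4 values shown sits.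

On these data alone, whether the rise belongs to the terminal ester or to the chain itself stays open. A carboxylic acid, an amine or an unbranched hydrocarbon chain at the same position would separate the two readings.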